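This account rests on a few compounds, and the source may have more. Where it says the series, first, only, none or still open, it means among the compounds named here.

Measured compounds:
- Compound 2, `O=C(O)Cn1c(SCCc2ccccc2)nc2ccccc21`: 881 nM
- Compound 1, `O=C(O)Cn1c(SCCOc2cccc3ccccc23)nc2ccccc21`: 2000 nM

In an assay on HEK293 cells for displacement of a labelled ligand from prostaglandin D2 receptor 2 (Homo sapiens) (a higher number here means a weaker inhibitor, a lower number a stronger inhibitor), compound 2 gives 881 nM, the lower of the two numbers recorded. Its nearest neighbour is compound 1, which in this assay gives 2000 nM, a gap that lies beyond the usual scatter of repeated measurements. Within the data shown here, no single-point step between measured compounds is available, so the two values show only that compound 2 is the stronger of the pair.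

Compound 3, `O=C(O)Cn1c(SCc2ccc(Br)cc2)nc2ccccc21`, has not yet been measured in this assay. Compared with compound 2 it differs in one place: 4-bromophenyl in place of benzyl on a saturated chain carbon bound to a sulfur. The change keeps the shared core and the thioether link of compound 2 intact and alters only the group carried on the saturated chain carbon bound to the sulfur.

Among the measured compounds shown here, since no step between measured compounds is recorded, the expectation for compound 3 rests on compound 2 alone, whose value in this assay is 881 nM. Compound 3 is expected to give 700 nM, within a range of 250 nM to 2000 nM. That estimate means a step from compound 2 to compound 3 of a 1.3-fold lower number from compound 2 to compound 3 (0.10 log units; within the scatter), which is expected to be small and in no clear direction beyond the scatter.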

Compound 3, half-maximal inhibitory concentration: 220 nM
The estimate for compound 3 lay 3.2-fold (0.50 log units) above the measured number; measured number below the stated range.
By their numbers in this assay, from the lowest: compound 3; then compound 2; then compound 1.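

In this assay, the group on the saturated chain carbon bound to a sulfur proves to be a place where a single change moves the number: 4-bromophenyl in place of benzyl gives a 4.0-fold lower number from compound 2 to compound 3 (0.60 log units; beyond the scatter). The two groups match in heavy atoms, in having one six-membered aromatic ring of carbon only, in having no hydrogen-bond donors or acceptors, and in carrying no net charge, so the same counts can go with clearly different numbers here; the only difference in these counts is that one carbon gives way to one bromine. Nothing measured here accounts for this step.

The change removes the carbon of the benzyl group and adds the bromine in a single move, so the compounds shown cannot say how much of the step belongs to each. A plain phenyl group on the same carbon would separate the two, while a chlorine in place of the bromine would show whether the step depends on bromine itself.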